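Carboxy to Hydroxymethyl on a Second Core

A few compounds are considered here, and "the series" means these few. Any claim that something is new, unique, unknown or untested is made for them only; others in the source may bear on it.

Measured compounds:
Compound 1, `C=CC(=O)Nc1ccc(Cn2nc(-c3ccc(Oc4ccccc4)cc3)cc2C(=O)O)cc1`, in a functional assay on JeKo-1 cells (Homo sapiens) for inhibition, read by luminescence and CellTiter-Glo, with a stated time of 72 h (on this read-out higher numbers stand for weaker inhibition and lower numbers for stronger inhibition), compound 1 gives > 60000 nM.
Compound 2, `C/C=C/C(=O)N1CCCC(n2nc(-c3ccc(Oc4ccccc4)cc3)cc2C(=O)O)C1`, in this assay compound 2 gives > 60000 nM.
Compound 3, `C=CC(=O)Nc1ccc(Cn2nc(-c3ccc(Oc4ccccc4)cc3)cc2CO)cc1`, in this assay compound 3 gives 8000 nM.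

The value of compound 1 is a limit of this assay and not a number. The value of compound 2 is likewise a limit, and the limit of > 60000 nM in this assay, at which 2 of the 3 values shown sit, is where two of the three values shown sit. For the measured compounds named here, compound 3 is the one compound with a number.

Compound 1 and compound 3 share a core and differ in one place: hydroxymethyl in place of carboxy on an aromatic carbon. This change produced an at least 7.5-fold lower number from compound 1 to compound 3 (0.87 log units; beyond the scatter).

Compound 2 carries a different core from compound 1; the difference between the two cores is not broken down here. Compound 4, `C/C=C/C(=O)N1CCCC(n2nc(-c3ccc(Oc4ccccc4)cc3)cc2CO)C1`, is not yet measured in this assay. It stands to compound 2 as compound 3 stands to compound 1, and the change is the same one: hydroxymethyl in place of carboxy on an aromatic carbon.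

Going by the values given here, since the only measured instance of this change, from compound 1 to compound 3, gave an at least 7.5-fold lower number from compound 1 to compound 3 (0.87 log units; beyond the scatter), a step of a similar size is expected on the core of compound 2, though compound 2 only gives a limit as its starting point, so the step from compound 2 to compound 4 is estimated as an at least 4.0-fold lower number from compound 2 to compound 4 (0.60 log units; beyond the scatter). Compound 4 is expected to give about 15000 nM in this assay, with a plausible range from 3000 nM to 60000 nM.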

Compound 4, half-maximal inhibitory concentration: > 60000 nM
Compound 4: a limit, no number; the forecaster's own chance of this, stated with the estimate: 30%; middle value at least 4.0-fold (0.60 log units) away from the limit.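

In this assay compound 4 gives > 60000 nM, which is a limit of the assay and not a number. Compound 2 also gives a limit, so no step can be read from compound 2 to compound 4. Most of the compounds shown now sit at one value: the limit of > 60000 nM in this assay, at which 3 of the 4 values shown sit.

The compounds shown leave open whether hydroxymethyl in place of carboxy on an aromatic carbon changes the value on the core of compound 2.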